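This account rests on a few compounds, and the source may have more. Where it says the series, first, only, none or still open, it means among the compounds named here.

Two compounds sharing one core have been run in a functional assay (aorta) with Oryctolagus cuniculus as the target; a higher number here means a weaker inhibitor, a lower number a stronger inhibitor. Compound 1, `Cc1oc(-c2nn(Cc3ccccc3F)c3ncccc23)nc1CO`, gives 1500 nM in this assay. Compound 2, `Nc1nc(-c2nn(Cc3ccccc3F)c3ncccc23)ncc1C1CCCC1`, gives 904000 nM, the highest of the two numbers; the gap to compound 1 lies well beyond the scatter, so compound 2 stands as the weaker of the pair by a wide margin. Compound 3, `NCc1cnc(-c2nn(Cc3ccccc3F)c3ncccc23)nc1N`, has not yet been measured. It differs from compound 2 in one place: aminomethyl in place of cyclopentyl on an aromatic carbon. Among the compounds with values here, no step between measured compounds matches this change, so its effect can only be guessed from where compound 2 stands. A step from compound 2 to compound 3 of a 3.0-fold lower number from compound 2 to compound 3 (0.48 log units; beyond the scatter) toward a lower number is expected, of modest size and with wide uncertainty. For compound 3 an estimate of 300000 nM is given, within a range from 30000 nM to 1000000 nM.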

Compound 3, half-maximal inhibitory concentration: 1400000 nM
Beside the measured number, compound 3's estimate is 4.7-fold (0.67 log units) below it; measured number outside the range, above it.
By their numbers in this assay, from the lowest: compound 1; then compounds 2 and 3 (each within the scatter of the next).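

Putting aminomethyl in place of cyclopentyl on this aromatic carbon gives a 1.5-fold higher number from compound 2 to compound 3 (0.19 log units; within the scatter) in this assay, so the two compounds cannot be told apart. At this position, then, the read-out does not separate a five-membered carbon ring with no hydrogen-bond donor or acceptor from a smaller open group that carries one of each, although this single pair is all that shows it. Nothing available offers an explanation for this result.

The compounds shown leave open whether a carboxylic acid, a hydroxymethyl group or a longer chain such as aminoethyl on this carbon would separate from compound 2 and compound 3. They also leave open whether a plain hydrogen or methyl group there would read any differently.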